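The compounds below may be only part of what the source reports. "The series", "measured", "known", "first", "only" and "open" are said of these compounds alone.

Compound 1 `CC(C)(C)OC(=O)N1CCC(c2coc3c(N4CCCc5cc(S(C)(=O)=O)ccc54)ncnc23)CC1`: 1%
Compound 2 `CS(=O)(=O)c1ccc2c(c1)CCN2c1ncnc2c(C3CCN(c4ncccn4)CC3)coc12`: 196%
Compound 3 `CN(c1ccc(S(C)(=O)=O)cc1F)c1ncnc2c(C3CCN(C(=O)OC(C)(C)C)CC3)coc12`: 6%

In a functional assay on cells for agonist activity at Glucose-dependent insulinotropic receptor (Homo sapiens), read by a luciferase reporter, with a stated time of 4 h (a lower number here means a smaller maximal response, a higher number a larger maximal response), compound 2 gives 196%, the highest of the three numbers; compound 3 and compound 1 both lie far lower, beyond the usual scatter. Compound 4 `CC(C)(C)OC(=O)N1CCC(c2coc3c(N4CCc5cc(S(C)(=O)=O)ccc54)ncnc23)CC1` has not yet been measured. It differs from compound 2 in one place: tert-butoxycarbonyl in place of pyrimidin-2-yl on an amine nitrogen in a ring. Compound 1 and compound 3 already carry this same tert-butoxycarbonyl on an amine nitrogen in a ring, and both show only a small maximal response in this assay, compound 1 giving 1% and compound 3 giving 6%. A large fall is therefore expected. Compound 4 is estimated to give 5%, with a range from 0% to 30%. This estimate means an expected step of a number 191 percentage points lower from compound 2 to compound 4 (beyond the scatter), a drop well beyond the scatter.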

Compound 4, largest response reached (Emax), in percent of the reference or control that the assay uses: 123%
Compound 4: middle estimate off by 118 percentage points, on the low side; measured number outside the range, above it.
By their numbers in this assay, from the lowest: compounds 1 and 3 (each within the scatter of the next); then compound 4; then compound 2.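

In this assay tert-butoxycarbonyl in place of pyrimidin-2-yl on this amine nitrogen in a ring brings a number 73 percentage points lower from compound 2 to compound 4 (beyond the scatter) but still leaves a large maximal response. Compound 4 and compound 1 share this group and differ in one other place, yet compound 1 gives 1% here, so tert-butoxycarbonyl alone does not set a near-zero response. Nothing measured here explains the step. From the compounds shown here alone, whether a pyridin-2-yl or an acetyl on this nitrogen would keep the response stays open. So does whether pyrimidin-2-yl would raise the response of compound 1.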